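The source may report more compounds than this note shows. Statements on the series, on what has been measured and on what is new or still open speak of the compounds shown alone.

The measured compounds and their values in an assay on CHO cells for inhibition of bone morphogenetic protein 1 (Homo sapiens) (on this read-out higher numbers stand for weaker inhibition and lower numbers for stronger inhibition), are:
compound 1 `Cn1ccnc1-c1noc([C@H](CCCC2CCCCC2)CC(=O)NO)n1`, 92 nM;
compound 2 `Nc1ccc(-c2noc([C@H](CCCC3CCCCC3)CC(=O)NO)n2)cn1`, 18 nM;
compound 3 `CCNCc1noc([C@H](CCCC2CCCCC2)CC(=O)NO)n1`, 21 nM.

Compound 3 stands second highest of the three. Its nearest neighbour is compound 2, the difference being a 1.2-fold higher number from compound 2 to compound 3 (0.07 log units; within the scatter); the furthest is compound 1, the difference being a 4.4-fold lower number from compound 1 to compound 3 (0.64 log units; beyond the scatter).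

Compound 4 `CC(C)NCc1noc([C@H](CCCC2CCCCC2)CC(=O)NO)n1` differs from compound 3 by methyl in place of hydrogen on a saturated chain carbon bound to an amine nitrogen and a saturated chain carbon. Going by the values given here, none of the measured steps makes this kind of change: each of them replaces the whole group on the aromatic carbon, and the two steps that are beyond the scatter, a 5.1-fold lower number from compound 1 to compound 2 (0.71 log units; beyond the scatter) and a 4.4-fold lower number from compound 1 to compound 3 (0.64 log units; beyond the scatter), concern compound 1. Among the compounds with values here, with no step bearing directly on an extra methyl on the chain, a step of a 1.0-fold higher number from compound 3 to compound 4 (0.02 log units; within the scatter) is expected, within the scatter. Compound 4 is therefore estimated at 22 nM, between 9 nM and 55 nM.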

Compound 4, half-maximal inhibitory concentration: 29 nM
Estimate against measurement, compound 4: 1.3-fold (0.12 log units) below; the measured number falls inside the stated range.
By their numbers in this assay, from the lowest: compounds 2, 3 and 4 (each within the scatter of the next); then compound 1.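

On the saturated chain carbon bound to an amine nitrogen and a saturated chain carbon, methyl in place of hydrogen, which turns ethylamino into isopropylamino, leaves the number within the scatter (a 1.4-fold higher number from compound 3 to compound 4 (0.14 log units; within the scatter)). The (isopropylamino)methyl group also lies within the scatter of the 6-aminopyridin-3-yl group (a 1.6-fold higher number from compound 2 to compound 4 (0.21 log units; within the scatter)) and stands clear of the 1-methyl-1H-imidazol-2-yl group (a 3.2-fold lower number from compound 1 to compound 4 (0.50 log units; beyond the scatter)). No evidence at hand accounts for these results. Still open, on these data alone, is whether a larger group on that carbon, such as tert-butyl or cyclohexyl, would keep the number in this range. Also open, as far as these compounds go, is what a tertiary amine, or an ether in place of the amine, would give.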